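The source may report more compounds than this note shows. Statements on the series, on what has been measured and on what is new or still open speak of the compounds shown alone.

Measured so far in a functional assay on the whole organism (Hindlimb, strain albino) with Mus musculus as the target, in the maximal electroshock model, with a stated time of 0.5 h (a lower number here means that less compound is needed, a higher number that more compound is needed for the effect), as working values
- compound 1 `CC(=O)N1N=C(Nc2nc3ccc(C)cc3s2)CC1c1ccc(O)cc1` gives 50.2 umol/kg
- compound 2 `CC(=O)N1N=C(Nc2nc3ccc([N+](=O)[O-])cc3s2)CC1c1ccc(O)cc1` gives 162 umol/kg
- compound 3 `COc1ccc(/C=C/C(=O)Nc2nc3ccccc3s2)cc1O` gives 495 umol/kg

Compound 1 has the lowest of the three numbers, and the other two lie beyond the scatter from it. Next is compound 4 `CC(=O)N1N=C(Nc2nc3ccc(C)cc3s2)CC1c1ccccc1`, with hydrogen in place of hydroxy on an aromatic carbon as its only change. Among the measured compounds shown here, the one measured step, a 3.2-fold higher number from compound 1 to compound 2 (0.51 log units; beyond the scatter), is modest, but it is nitro in place of methyl, a different change that bears only weakly here. For the measured compounds named here, no measured step removes the hydroxy, so the data give no direction, and no step beyond the scatter is expected in this assay. The expected change is a 1.1-fold lower number from compound 1 to compound 4 (0.05 log units; within the scatter), an estimate only. For compound 4 the expected value is 45 umol/kg, with an estimated range from 18 umol/kg to 120 umol/kg.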

Compound 4, dose for half-maximal effect: 106 umol/kg
Beside the measured number, compound 4's estimate is 2.4-fold (0.37 log units) below it; the measured number falls inside the stated range.
By their numbers in this assay, from the lowest: compound 1; then compounds 4 and 2 (each within the scatter of the next); then compound 3.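

In this assay, the series now has its first reading at this position, and going from 4-hydroxyphenyl to phenyl raises the number (a 2.1-fold higher number from compound 1 to compound 4 (0.32 log units; beyond the scatter)). The hydroxy therefore counts in this assay, though the step is modest. Nothing at hand gives a reason for this step.

Open, going by these compounds, is whether a methoxy, an amine or a fluorine at the same place would match the hydroxy or the hydrogen. Also open, on these data alone, is whether the step holds when the nitro of compound 2 replaces the methyl.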